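Opening a cyclic urea on the side chain of compound 1

The source may hold more compounds than are shown below. What is called first, only, known or untested is meant among the compounds shown, and "the series" means these compounds.

Measured compounds:
compound 1 `O=C1NCCN1CCN1CCC(c2cn(-c3ccc(F)cc3)c3cc(Cl)ccc23)CC1` — 9.6 nM
compound 2 `O=C1NCCN1CCN1CCC(c2cn(-c3ccc(F)cc3)c3cc(C(F)(F)F)ccc23)CC1` — 33 nM

Both compounds were tested in an assay on cell membranes for displacement of a labelled ligand from Adrenergic receptor alpha-1 (Rattus norvegicus); a lower number here means a stronger inhibitor, a higher number a weaker inhibitor. Among these two numbers compound 1 gives the lower one, and the step of a 3.4-fold higher number from compound 1 to compound 2 (0.54 log units; beyond the scatter) separates it from compound 2. Compound 3 `CC(C)NC(=O)N(C)CCN1CCC(c2cn(-c3ccc(F)cc3)c3cc(Cl)ccc23)CC1` keeps the chloro-bearing core of compound 1 and changes the side chain instead: (isopropylcarbamoyl)(methyl)amino in place of 2-oxoimidazolidin-1-yl on a saturated chain carbon, two bonds along the chain from an amine nitrogen in a ring. Going by the values given here, the single measured step concerns a different place, the aromatic carbon, and so says nothing direct about swapping one urea for another on the chain. Among the compounds with values here, with no step to lean on, only a cautious guess is possible: the count of donors and acceptors is unchanged, but the ring is gone, so a small weakening at most is expected, about a 2.1-fold higher number from compound 1 to compound 3 (0.32 log units; beyond the scatter). Compound 3 is therefore estimated at 20 nM, with a range from 5 nM to 80 nM.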

Compound 3, half-maximal inhibitory concentration: 26 nM
The estimate for compound 3 lay 1.3-fold (0.11 log units) below the measured number, and the stated range covers the measured number.
By their numbers in this assay, from the lowest: compound 1; then compounds 3 and 2 (each within the scatter of the next).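

In this assay, the saturated chain carbon turns out to be a second place where a change can be read: a 2.7-fold higher number from compound 1 to compound 3 (0.43 log units; beyond the scatter) follows when the 2-oxoimidazolidin-1-yl ring gives way to the open (isopropylcarbamoyl)(methyl)amino group. The step is modest, and compound 3 at 26 nM shows that, in this pair, binding in the nanomolar range does not depend on keeping the urea closed in a five-membered ring. Nothing measured here explains why the number rises.

This single change removes the ring and also adds carbon atoms, so the compounds shown cannot tell which of the two matters. The open question concerns groups such as a six-membered cyclic urea, an open urea with methyl in place of isopropyl, or a simple amide on the same chain.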